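Longer acid arm on the shared core: compound 4

This account rests on a few compounds, and the source may have more. Where it says the series, first, only, none or still open, it means among the compounds named here.

Three compounds of the series have been run in a functional assay on a cell-free system (Platelet, plasma, Homo sapiens) for inhibition; on this read-out higher numbers stand for weaker inhibition and lower numbers for stronger inhibition. Compound 1 `O=C(O)CN1Cc2ccc(NC(=O)c3ccc(C4CCNCC4)cc3)cc2C1=O` gives 24000 nM, the highest of the three numbers. Among the compounds with values here, compound 2 `CC(CC(=O)O)N1Cc2ccc(NC(=O)CCCC3CCNCC3)cc2C1=O` gives 5400 nM, and compound 3 `CC(CC(=O)O)N1Cc2ccc(NC(=O)c3ccc(N4CCNCC4)cc3)cc2C1=O` gives 3740 nM; both lie below compound 1 by more than the usual scatter, yet each differs from compound 1 in more than one place, so no single-point step between measured compounds exists. Both carry a longer acid chain than compound 1, together with a changed amide part.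

Compound 4 `O=C(O)CCCN1Cc2ccc(NC(=O)c3ccc(C4CCNCC4)cc3)cc2C1=O` is not yet measured. It keeps the amide part of compound 1 and differs only in the acid arm, where carboxy leaves and 2-carboxyethyl enters: 2-carboxyethyl in place of carboxy on a saturated chain carbon bound to an amide-type nitrogen in a ring. A moderate drop in this assay is expected, because compound 2 gives 5400 nM and compound 3 gives 3740 nM with their longer chains, though their other changes leave this uncertain. The expected step is a 3.0-fold lower number from compound 1 to compound 4 (0.48 log units; beyond the scatter), beyond the scatter. Compound 4 is estimated at 8000 nM, within 2500 nM to 30000 nM.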

Compound 4, half-maximal inhibitory concentration: 410000 nM
Beside the measured number, compound 4's estimate is 51-fold (1.71 log units) below it; measured number outside the range, above it.
By their numbers in this assay, from the lowest: compounds 3 and 2 (each within the scatter of the next); then compound 1; then compound 4.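

In this assay, within the data shown here, the change of carboxymethyl to 3-carboxypropyl on the amide-type nitrogen in a ring gives a 17-fold higher number from compound 1 to compound 4 (1.23 log units; beyond the scatter) and is the first single-place step. With the amide part of compound 1 held fixed, this longer unbranched acid arm alone weakens inhibition by a large margin. The lower numbers of compound 2 and compound 3 cannot be credited to a longer chain, as each differs from compound 1 in more than one place. Nothing on hand accounts for the size of this loss.

Open, as far as these compounds go, is whether the loss grows gradually with chain length or appears abruptly, which an unbranched 2-carboxyethyl arm on that nitrogen with the amide part of compound 1 would test. Also open, from the compounds shown here alone, is whether a methyl branch on the longer acid chain changes the outcome when that amide part is held fixed.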